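Stripping the pyridine: what to expect for compound 3

This account rests on a few compounds, and the source may have more. Where it says the series, first, only, none or still open, it means among the compounds named here.

Two measured compounds share a core and differ only in the group carried on a saturated chain carbon bound to a nitrogen on an aromatic ring. In a functional assay on the whole organism (strain Sprague-Dawley) for inhibition, with Rattus norvegicus as the target, read by paw edema, with a stated time of 180 min, at a dose of 20 mg/kg by the oral route (a higher number here means a stronger effect of the compound at the dose given, a lower number a weaker effect), compound 1 `COc1ccnc(CNc2ccc3c(c2)nc(C)n3C[C@@H](O)[C@H]2O[C@H](O)[C@@H](O)[C@H]2O)c1OC` gives 62%. In this assay compound 2 `COc1c(C)cnc(CNc2ccc3c(c2)nc(C)n3C[C@@H](O)[C@H]2O[C@H](O)[C@@H](O)[C@H]2O)c1C` gives 50%, the lower of the two numbers. Among the compounds with values here, the single recorded step, a number 12 percentage points lower from compound 1 to compound 2 (beyond the scatter), shows that changing what sits on that group shifts the read-out modestly. Compound 3 `Cc1nc2cc(NCc3ccccn3)ccc2n1C[C@@H](O)[C@H]1O[C@H](O)[C@@H](O)[C@H]1O` is not yet measured; it differs from compound 2 in this way: pyridin-2-yl in place of 4-methoxy-3,5-dimethylpyridin-2-yl on a saturated chain carbon bound to a nitrogen on an aromatic ring. Within the data shown here, no measured step removes all three of those substituents at once, so the only guide is the modest size of the one step seen, pointing to a further small loss rather than a large one. Compound 3 is therefore expected to give about 42% in this assay, within a range from 22% to 62%. That estimate means a step of a number 8 percentage points lower from compound 2 to compound 3 (within the scatter), which might not exceed the usual scatter.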

Compound 3, a percentage reported as inhibition, in the whole organism at one dose (the size of the read-out at that dose, not a potency): 47%
Compound 3: the middle estimate sits 5 percentage points below what was measured; low and high end bracket the measured number.
By their numbers in this assay, from the lowest: compounds 3 and 2 (each within the scatter of the next); then compound 1.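

Replacing 4-methoxy-3,5-dimethylpyridin-2-yl with unsubstituted pyridin-2-yl on a saturated chain carbon bound to a nitrogen on an aromatic ring gives a number 3 percentage points lower from compound 2 to compound 3 (within the scatter), so in this assay these three substituents can go without a change that stands out from the scatter. Replacing 3,4-dimethoxypyridin-2-yl with the same unsubstituted ring gives a number 15 percentage points lower from compound 1 to compound 3 (beyond the scatter), which leaves compound 1 as the only one of the three set apart, with the higher number tied to its two methoxy groups. Nothing measured here explains these numbers.

As far as these compounds go, whether a single methoxy group on the pyridine would be enough to reach the number of compound 1 remains open. So does the effect of an amine or a carboxylic acid on that ring, or of a plain phenyl ring in its place.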